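Swapping a hydroxyl for a carbonyl on the piperidine arm

This account rests on a few compounds, and the source may have more. Where it says the series, first, only, none or still open, it means among the compounds named here.

Within the data shown here, the three compounds measured so far share one core and differ only in the amine carried on a saturated chain carbon bound to an aromatic carbon. In an assay on CHO-K1 cells for antagonist activity at adenosine receptor A1 (Homo sapiens), read by a beta-galactosidase reporter, with stated times of 15 min and 6 h (on this read-out higher numbers stand for weaker inhibition and lower numbers for stronger inhibition), compound 1 `CCN(CC)Cc1cc2c(N)nc(-c3ccco3)nc2s1` gives 2130 nM, compound 2 `Nc1nc(-c2ccco2)nc2sc(CNC3CCCCC3)cc12` gives 2480 nM, and compound 3 `Nc1nc(-c2ccco2)nc2sc(CN3CCC(O)CC3)cc12` gives 4000 nM. Compound 3 holds the highest of the three numbers, yet its distance to the others is small: a 1.9-fold higher number from compound 1 to compound 3 (0.27 log units; within the scatter) and a 1.6-fold higher number from compound 2 to compound 3 (0.21 log units; within the scatter) both fall within the scatter, as does a 1.2-fold higher number from compound 1 to compound 2 (0.07 log units; within the scatter). Compound 4 `Nc1nc(-c2ccco2)nc2sc(CN3CCC(=O)CC3)cc12` continues this series with a change at the same place: 4-oxopiperidin-1-yl in place of 4-hydroxypiperidin-1-yl on a saturated chain carbon bound to an aromatic carbon. Every measured step here has altered the amine at this position, and none has moved the number beyond the scatter, so the expectation for a 1.1-fold higher number from compound 3 to compound 4 (0.05 log units; within the scatter) is no shift beyond the scatter in either direction. Compound 4 is therefore estimated at 4500 nM in this assay, with a likely range from 2000 nM to 10000 nM.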

Compound 4, inhibition constant: 2720 nM
For compound 4 the middle estimate is 1.7-fold (0.22 log units) above the measured one; measured number inside the range.
By their numbers in this assay, from the lowest: compounds 1, 2, 4 and 3 (each within the scatter of the next).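

Exchanging 4-hydroxypiperidin-1-yl for 4-oxopiperidin-1-yl removes the hydrogen-bond donor from this group while keeping its ring and heavy-atom count, and in this assay the result stays within the scatter (a 1.5-fold lower number from compound 3 to compound 4 (0.17 log units; within the scatter)). Compound 4 also stays within the scatter of the compounds carrying cyclohexylamino (a 1.1-fold higher number from compound 2 to compound 4 (0.04 log units; within the scatter)) and diethylamino (a 1.3-fold higher number from compound 1 to compound 4 (0.11 log units; within the scatter)), so neither ring oxygen form stands apart from these amines on a saturated chain carbon bound to an aromatic carbon. No supporting evidence is available to explain this result.

The four compounds therefore reveal no group at this place that clearly changes the number. From the compounds shown here alone, whether a carboxylic acid on the piperidine ring, a morpholine ring or a longer chain leading to the amine would move it beyond the scatter remains open.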